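This account rests on a few compounds, and the source may have more. Where it says the series, first, only, none or still open, it means among the compounds named here.

Series notes. Going by the values given here, in an assay on isolated protein for inhibition of Indoleamine 2,3-dioxygenase 1 (Homo sapiens), read by HPLC, with a stated time of 60 min, in the presence of a further agent that is not named here (on this read-out lower numbers stand for stronger inhibition and higher numbers for weaker inhibition), compound 1 `COc1ccccc1Sc1c[nH]c2ccc(Cl)cc12` gives 17500 nM, the only numerical value in the set. Compound 2 `COc1ccccc1S(=O)(=O)c1c[nH]c2ccc(Cl)cc12` sits at a limit of the assay, > 200000 nM. Compound 3 `COc1ccccc1C(=O)c1c[nH]c2ccc(Cl)cc12` likewise reaches only a limit, > 200000 nM. Among the compounds with values here, compound 1 therefore stands alone as the one compound with a measured number, while the limit of > 200000 nM in this assay, at which 2 of the 3 values shown sit, holds the other two. Compound 4 `Clc1ccc2[nH]cc(Sc3ccccc3)c2c1` is not yet measured; it differs from compound 1 by hydrogen in place of methoxy on an aromatic carbon. Within the data shown here, no measured pair in the set follows such a change, so the size of the step is open; a step within the scatter, in either direction, is expected. For compound 4 the expected value in this assay is 25000 nM, within 8000 nM to 80000 nM. The estimated step is a 1.4-fold higher number from compound 1 to compound 4 (0.15 log units; within the scatter).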

Compound 4, half-maximal inhibitory concentration: > 200000 nM
Compound 4 gave a limit, no number; the forecaster's own chance of this, stated with the estimate: 15%; middle value at least 8.0-fold (0.90 log units) away from the limit.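

At this place, ortho to a large group, hydrogen in place of methoxy on an aromatic carbon is far from a neutral change: in this assay it brings an at least 11-fold higher number from compound 1 to compound 4 (1.05 log units; beyond the scatter). Of this pair, only the compound carrying the methoxy group gives a number. Compound 4 reads only as a limit, so the true size of the step stays unfixed: the limit of > 200000 nM in this assay, at which 3 of the 4 values shown sit.

From the compounds shown here alone, whether an ethoxy group, a hydroxyl group or a fluorine atom at this place would keep a measurable value remains open. Also open, going by these compounds, is whether methoxy elsewhere on this ring would do the same.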